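From isopropyl to phenyl on a shared core

The source may hold more compounds than are shown below. What is called first, only, known or untested is meant among the compounds shown, and "the series" means these compounds.

In a functional assay on the whole organism (Myocardium) with Canis familiaris (Canis lupus familiaris) as the target, at a dose of 8.75 mg/kg by the intravenous route (on this read-out lower numbers stand for an effect already at smaller amounts and higher numbers for an effect only at larger amounts of compound), compound 1 `Cc1nc(O)nc2ccc(N(C)C)cc12` gives 1.2 mg/kg, compound 2 `CCc1nc(O)nc2cc(OC)c(OC)cc12` gives 3.4 mg/kg and compound 3 `COc1cc2nc(O)nc(C(C)C)c2cc1OC` gives 1.39 mg/kg. Compound 3 thus lies within the scatter of compound 1 and clearly below compound 2. Compound 4 `COc1cc2nc(O)nc(-c3ccccc3)c2cc1OC` differs from compound 3 at one place, an aromatic carbon next to the ring nitrogen: phenyl in place of isopropyl on an aromatic carbon. Among the measured compounds shown here, the one measured step at this place is a 2.4-fold lower number from compound 2 to compound 3 (0.39 log units; beyond the scatter), a modest change made by adding a methyl to the saturated chain. For the measured compounds named here, no measured step puts a ring there, so it is only a weak guide. The expected change is a 1.2-fold lower number from compound 3 to compound 4 (0.06 log units; within the scatter), which stays within the scatter. Compound 4 is estimated at 1.2 mg/kg, with an expected range of 0.4 mg/kg to 3.6 mg/kg.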

Compound 4, dose for half-maximal effect: 4.1 mg/kg
For compound 4 the middle estimate is 3.4-fold (0.53 log units) below the measured one, and the stated range ends below it.
By their numbers in this assay, from the lowest: compounds 1 and 3 (each within the scatter of the next); then compounds 2 and 4 (each within the scatter of the next).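

In this assay, putting phenyl in place of isopropyl on this aromatic carbon gives a 2.9-fold higher number from compound 3 to compound 4 (0.47 log units; beyond the scatter) and so loses what isopropyl had gained over ethyl. Phenyl in place of ethyl gives a 1.2-fold higher number from compound 2 to compound 4 (0.08 log units; within the scatter), so these two groups cannot be told apart here, and among the three groups compared at this carbon only isopropyl stands apart. No measurement at hand explains this difference. As far as these compounds go, it remains open how a saturated ring such as cyclohexyl or a longer chain such as butyl would read at this carbon. From the compounds shown here alone, an amine there is equally open.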